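Replacing fluorophenyl with chlorophenyl on a sulfonamide scaffold

This account rests on a few compounds, and the source may have more. Where it says the series, first, only, none or still open, it means among the compounds named here.

Measured compounds:
- compound 1, `CC1CCN(C2CCN(S(=O)(=O)c3cccc(Br)c3)CC2)CC1`: > 5000 nM
- compound 2, `CC1CCN(C2CCN(S(=O)(=O)c3cccc(-c4ccccc4F)c3)CC2)CC1`: > 5000 nM

Both compounds share a core in which a sulfonyl group carries an aromatic ring. In an ADME assay on HCT-116 cells (Homo sapiens) for cytotoxicity, read by CellTiter-Glo, with a stated time of 72 h (on this read-out higher numbers stand for weaker inhibition and lower numbers for stronger inhibition), compound 1 gives only a limit of the assay, > 5000 nM. In this assay compound 2 likewise gives only a limit, > 5000 nM. Both values sit at the limit of > 5000 nM in this assay, at which 2 of the 2 values shown sit, so the size of the step that the two limits leave unreadable from compound 1 to compound 2 cannot be read from them, and the two compounds cannot be placed in any order relative to each other.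

The next compound, compound 3, `CC1CCN(C2CCN(S(=O)(=O)c3cccc(-c4ccc(Cl)cc4)c3)CC2)CC1`, differs from compound 2 in one place: 4-chlorophenyl in place of 2-fluorophenyl on an aromatic carbon.

Going by the values given here, only one measured step exists, and it is unreadable, so it gives no guidance on the size or direction of the change to compound 3. Among the compounds with values here, what the numbers do show is that every compound so far has stayed at the limit, which makes it likely that compound 3 also returns a limit rather than a number. Compound 3 is therefore expected to show a step that the limit leaves unreadable from compound 2 to compound 3, a step that would remain hidden if the assay again reports only its limit. The estimate for compound 3 in this assay is 9000 nM, with a range from 3000 nM to 30000 nM.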

Compound 3, half-maximal inhibitory concentration: > 5000 nM
Compound 3: only a limit was reported; the forecaster's own chance of this, stated with the estimate: 80%; the middle value is on the limit's open side.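

In this assay compound 3 gives > 5000 nM, which is again only a limit of the assay. Going by these compounds alone, no step among compound 1, compound 2 and compound 3 can therefore be read: the limit of > 5000 nM in this assay, at which 3 of the 3 values shown sit. The compounds shown leave open how strongly each one inhibits these cells, and whether changing the group on this aromatic carbon makes any difference.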